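From vinyl to furan-2-yl on a carbonyl carbon

The source may hold more compounds than are shown below. What is called first, only, known or untested is meant among the compounds shown, and "the series" means these compounds.

In an ADME assay on Vero cells (Chlorocebus sabaeus) for cytotoxicity, read by MTT assay, with a stated time of 48 h (a lower number here means a stronger inhibitor, a higher number a weaker inhibitor), compound 1 (`O=C(OC1CCC(CN2CCN(c3cc(=O)c4cc(C(F)(F)F)cc([N+](=O)[O-])c4s3)CC2)CC1)C1CCC1`) gives > 64 ug/mL, which is a limit and not a number. In this assay, compound 2 (`C=CC(=O)OC1CCC(CN2CCN(c3cc(=O)c4cc(C(F)(F)F)cc([N+](=O)[O-])c4s3)CC2)CC1`) gives > 64 ug/mL, which is likewise a limit. Going by the values given here, the series so far therefore rests entirely on (the limit of > 64 ug/mL in this assay, at which 2 of the 2 values shown sit), and compound 2 has no measured number to stand on.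

Compound 3 (`O=C(OC1CCC(CN2CCN(c3cc(=O)c4cc(C(F)(F)F)cc([N+](=O)[O-])c4s3)CC2)CC1)c1ccco1`) differs from compound 2 in one place, with furan-2-yl in place of vinyl on a carbonyl carbon.

Among the compounds with values here, only one measured step bears on this change, the replacement of cyclobutyl by vinyl on the same carbonyl carbon. That is a step that the two limits leave unreadable from compound 1 to compound 2, so it offers no size to carry forward.

The expectation rests on compound 2 and its limit of > 64 ug/mL. The expected step is a number no higher from compound 2 to compound 3 (the limit leaves the size open), which should stay within the scatter and has no direction that can be foreseen. Compound 3 is expected near 64 ug/mL, with an estimated range from 32 ug/mL to 128 ug/mL. Another limit in this assay is the likeliest report.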

Compound 3, half-maximal inhibitory concentration: > 64 ug/mL
Compound 3: a limit, no number (the forecaster's own chance of this, stated with the estimate: 85%); the middle value sits exactly at the limit.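

In this assay compound 3 gives > 64 ug/mL, which is a limit and not a number. No step among compound 1, compound 2 and compound 3 can be read, because all three rest on the same limit: the limit of > 64 ug/mL in this assay, at which 3 of the 3 values shown sit.

The compounds shown leave open whether the group on this carbonyl carbon changes the read-out in this assay at all.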